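The source may hold more compounds than are shown below. What is called first, only, known or untested is meant among the compounds shown, and "the series" means these compounds.

Working notes on the series. Compound 1 `O=C(CSc1nnnn1-c1ccccc1)N/N=c1/scc(-c2ccc(Br)cc2)n1-c1ccccc1` and compound 2 `Cc1ccc(-c2cs/c(=N/NC(=O)CSc3nnnn3-c3ccccc3)n2-c2ccccc2)cc1` share a core and differ only by methyl in place of bromo on an aromatic carbon. In a functional assay on C6 cells (Rattus norvegicus) for cytotoxicity, read by MTT assay, with a stated time of 24 h, tested at 50 ug/mL (a lower number here means a stronger effect, a higher number a weaker effect of the compound at the concentration tested), compound 1 gives 32%, and compound 2 gives 29.5%. The step of a number 2.5 percentage points lower from compound 1 to compound 2 (within the scatter) lies within the scatter. Among the compounds with values here, on the numbers so far compound 2 stands at the lower of the two, with compound 1 within the scatter of it.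

Compound 3 `Cc1ccc(-c2cs/c(=N/NC(=O)CSc3nncn3C)n2-c2ccccc2)cc1` differs from compound 2 by 4-methyl-4H-1,2,4-triazol-3-yl in place of 1-phenyl-1H-tetrazol-5-yl on a sulfur. Within the data shown here, no measured step touches this place: the single step recorded concerns an aromatic carbon elsewhere and was itself within the scatter, so it offers no guide to size or direction here. Among the measured compounds shown here, with only two numbers to rest on, no step beyond the scatter is assumed and the range is kept wide. Compound 3 is expected to give about 32% in this assay, between 15% and 55%. The expected step is then a number 2.5 percentage points higher from compound 2 to compound 3 (within the scatter).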

Compound 3, a percentage reported as activity, at one concentration (the size of the read-out at that concentration, not a potency): 53.8%
Estimate against measurement, compound 3: 21.8 percentage points below; low and high end bracket the measured number.
By their numbers in this assay, from the lowest: compounds 2 and 1 (each within the scatter of the next); then compound 3.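

In this assay, within the data shown here, the group on the sulfur is the first place where a change carries beyond the scatter: the step is a number 24.3 percentage points higher from compound 2 to compound 3 (beyond the scatter) and means a weaker effect at the concentration tested, whereas the aromatic carbon gave only a number 2.5 percentage points lower from compound 1 to compound 2 (within the scatter). On this single pair, 4-methyl-4H-1,2,4-triazol-3-yl does not match 1-phenyl-1H-tetrazol-5-yl on this sulfur, and the change replaces the ring and also removes the six-membered aromatic ring. No measurement bears on the reason for this step.

The compounds shown leave open whether the five-membered ring or the phenyl accounts for the step, since both change together. A 1-methyl-1H-tetrazol-5-yl or 4-phenyl-4H-1,2,4-triazol-3-yl group on the same sulfur would separate the two.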